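A few compounds are considered here, and "the series" means these few. Any claim that something is new, unique, unknown or untested is made for them only; others in the source may bear on it.

Working notes on the series. Compound 1, `CC(=O)N1N=C(c2ccc(C)cc2)CC1c1cn(-c2ccccc2)nc1-c1ccc(Cl)c(Cl)c1`, and compound 2, `Fc1ccc(C2=NN(c3ccccc3)C(c3cn(-c4ccccc4)nc3-c3ccc(Cl)c(Cl)c3)C2)cc1`, were tested in a functional assay on the whole organism (strain Wistar) for inhibition, with Rattus norvegicus as the target, read by paw edema, with stated times of 30 min and 60 min, at a dose of 50 mg/kg by the oral route; on this read-out higher numbers stand for more inhibition at the one dose given (going by the name of the read-out) and lower numbers for less inhibition. Compound 1 gives 59.5% in this assay. Compound 2 gives 55.7% and stands as the lower of the two numbers, with compound 1 the nearest neighbour at a gap that lies within the scatter; no ordering of the two can be drawn from this. For the measured compounds named here, compound 1 and compound 2 differ in more than one place, so no single step between them is recorded.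

Compound 3, `CC(=O)N1N=C(c2ccc(F)cc2)CC1c1cn(-c2ccccc2)nc1-c1ccc(Cl)c(Cl)c1`, is not yet measured. It differs from compound 2 in one place: acetyl in place of phenyl on an amine nitrogen in a ring. Going by the values given here, no measured pair isolates this change. Since compound 1, which carries the same acetyl group on the ring nitrogen, gives 59.5%, the expected step from compound 2 is a number 2.3 percentage points higher from compound 2 to compound 3 (within the scatter), that is, none beyond the scatter. Compound 3 is therefore estimated at 58%, in the range 46% to 70%.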

Compound 3, a percentage reported as inhibition, in the whole organism at one dose (the size of the read-out at that dose, not a potency): 59.5%
Beside the measured number, compound 3's estimate is 1.5 percentage points below it, and the stated range covers the measured number.
By their numbers in this assay, from the lowest: compounds 2, 1 and 3 (each within the scatter of the next).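

In this assay, the step at the ring nitrogen can now be read from a measured pair: acetyl in place of phenyl on an amine nitrogen in a ring gives a number 3.8 percentage points higher from compound 2 to compound 3 (within the scatter), so replacing the aromatic ring with acetyl at this position produces no step beyond the scatter. The other new pair, with fluoro in place of methyl on an aromatic carbon, gives no change at the digits printed from compound 1 to compound 3 (within the scatter), so this change also produces no step beyond the scatter. Nothing available explains either result.

The compounds shown leave open whether an amine or a longer chain ending in a carboxylic acid on the ring nitrogen would also stay within the scatter of acetyl and phenyl. On these data alone, each number is also a reading at one dose rather than a potency, so whether these compounds would separate at other doses remains open.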